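The compounds below may be only part of what the source reports. "The series", "measured", "known", "first", "only" and "open" are said of these compounds alone.

Compound 1 `C=C1C(=O)O[C@H]2CC3=C[C@H](C/C(C)=C/[C@@H](OC(=O)c4ccc(C(F)(F)F)cc4)[C@H]12)OC3=O` was tested in a functional assay on NCI-H460 cells (Homo sapiens) for cytotoxicity, read by MTT assay, with a stated time of 48 h (on this read-out higher numbers stand for weaker inhibition and lower numbers for stronger inhibition), where it gives > 10000 nM, a figure that is a limit of the assay and not a measured number. Two other esters on the same core have been measured. Compound 2 `C=C1C(=O)O[C@H]2CC3=C[C@H](C/C(C)=C/[C@@H](OC(=O)/C=C/c4ccc(N(C)C)cc4)[C@H]12)OC3=O` gives 1300 nM in this assay, and compound 3 `C=C1C(=O)O[C@H]2CC3=C[C@H](C/C(C)=C/[C@@H](OC(=O)C45CCC(C)(C(=O)O4)C5(C)C)[C@H]12)OC3=O` gives 2000 nM. Both changes start from compound 1: an at least 7.6-fold lower number from compound 1 to compound 2 (0.88 log units; beyond the scatter) and an at least 5.0-fold lower number from compound 1 to compound 3 (0.69 log units; beyond the scatter). Between the two, a 1.5-fold higher number from compound 2 to compound 3 (0.19 log units; within the scatter).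

Compound 4 `C=C1C(=O)O[C@H]2CC3=C[C@H](C/C(C)=C/[C@@H](OC(=O)CC(C)C)[C@H]12)OC3=O` is not yet measured. It differs from compound 1 in one place: isobutyl in place of 4-(trifluoromethyl)phenyl on a carbonyl carbon. For the measured compounds named here, the steps that bear on it are the two measured replacements of the same group on the same carbonyl carbon, which both gave an at least modest lower number, although because compound 1 stands only at the limit of > 10000 nM in this assay, at which 1 of the 3 values shown sits, the true size of either step is not known. A lower number than compound 1 is therefore expected for compound 4, and the step is estimated as an at least 3.3-fold lower number from compound 1 to compound 4 (0.52 log units; beyond the scatter). With that in mind, compound 4 is expected to give about 3000 nM in this assay, with a range from 800 nM to 10000 nM.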

Compound 4, half-maximal inhibitory concentration: 3800 nM
Compound 4: the middle estimate sits 1.3-fold (0.10 log units) below what was measured; the range from low to high includes it.
By their numbers in this assay, from the lowest: compounds 2, 3 and 4 (each within the scatter of the next, the first and the last beyond it). At a limit, above all of these: compound 1.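

An isobutyl ester with no ring in the entering group also sits lower, with an at least 2.6-fold lower number from compound 1 to compound 4 (0.42 log units; beyond the scatter) in this assay, so among the compounds shown the drop on replacing 4-(trifluoromethyl)phenyl on this carbonyl carbon does not depend on a ring in the new group. The much larger group with two rings and the small isobutyl group stay close, with a 1.9-fold higher number from compound 3 to compound 4 (0.28 log units; within the scatter), whereas a 2.9-fold higher number from compound 2 to compound 4 (0.47 log units; beyond the scatter) gives the only gap between two measured numbers on this carbonyl carbon that lies beyond the scatter. How far isobutyl truly lies from 4-(trifluoromethyl)phenyl stays unknown because that step rests on a limit: the limit of > 10000 nM in this assay, at which 1 of the 4 values shown sits.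

The compounds shown leave open whether the edge of compound 2 over compound 4 goes with the dimethylamino group, the ethenyl link or the phenyl ring, since these parts are never varied alone. They also leave open how a longer chain, an amine or a carboxylic acid in place of isobutyl on this carbonyl carbon would read on the same core.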